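The source may report more compounds than this note shows. Statements on the series, on what has been measured and on what is new or still open speak of the compounds shown alone.

Measured so far:
compound 1, `CN1CCC2=CC[C@H](OCc3ccccc3)C[C@@H]21`; in an assay on HEK293 cells for displacement of a labelled ligand from Neuronal acetylcholine receptor; alpha4/beta2 (Rattus norvegicus), with a stated time of 4 h (a lower number here means a stronger inhibitor, a higher number a weaker inhibitor), compound 1 gives 300000 nM.
compound 2, `CO[C@H]1CC=C2CCN[C@H]2C1`; in this assay compound 2 gives 300000 nM.

Compound 2 stands level with compound 1 at the digits shown; the nearest measured compound is compound 1, and the two show no change between them beyond the scatter. Both sit at the weak end of the numbers, with nothing yet to separate them.

The next compound, compound 3, `O[C@H]1CC=C2CCN[C@H]2C1`, differs from compound 2 by hydrogen in place of methyl on an oxygen on a saturated carbon; cut one bond further out, the difference reads methoxy to hydroxy. No step between measured compounds is available that would calibrate a change of this kind in this assay.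

For the measured compounds named here, with compound 2 at 300000 nM and compound 1 at the same level, and with no step on record pointing elsewhere, the expectation for compound 3 is no change beyond the scatter in this assay. The expected step is no change at the digits printed from compound 2 to compound 3 (within the scatter). Compound 3 is therefore estimated at 300000 nM, with a range from 100000 nM to 1000000 nM.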

Compound 3, inhibition constant: > 300000 nM
Compound 3: only a limit was reported; the forecaster's own chance of this, stated with the estimate: 50%; the middle value lies on the limit itself.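

In this assay compound 3 is reported only as a limit, > 300000 nM. Methoxy to hydroxy at this place gives a number no lower from compound 2 to compound 3 (the limit leaves the size open), so taking off the methyl brings no lower number here, and the size of the step cannot be read. This is the first single-place change on record for the series, and it gives a direction only, bounded on one side, with the hydroxy compound resting on a limit and not on a measured number: the limit of > 300000 nM in this assay, at which 1 of the 3 values shown sits.

The compounds shown leave open whether an ethoxy group, an acetate ester or an amino group on this saturated carbon would give a readable number in this assay. How hydrogen in place of methyl reads on a stronger member of the series also stays open: compound 2 gives 300000 nM, and no stronger starting point for this change is shown.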